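The compounds below may be only part of what the source reports. "The series", "measured", "known", "first", "only" and "open" are said of these compounds alone.

Measured in a functional assay on KG-1 cells (Homo sapiens) for cytotoxicity, read by luminescence and CellTiter-Glo, with a stated time of 3 days; on this read-out lower numbers stand for stronger inhibition and higher numbers for weaker inhibition:

Compound 1 `O=C(Nc1cc(C(F)(F)F)cc(C(F)(F)F)c1)c1cc(Cl)c(F)cc1O`: 470 nM
Compound 2 `O=C(Nc1cc(C(F)(F)F)cc(C(F)(F)F)c1)c1cc(Br)c(-c2ccccc2)cc1O`: 300 nM

For the measured compounds named here, only these two compounds have numbers so far. In this assay compound 2 gives 300 nM, and compound 1 gives 470 nM. The two values lie within the usual scatter of each other, so neither can be ranked ahead of the other.

The next compound to be tested is compound 3 `O=C(Nc1cc(C(F)(F)F)cc(C(F)(F)F)c1)c1cc(Br)c(F)cc1O`. It has fluoro in place of phenyl on an aromatic carbon. Going by the values given here, no measured pair differs in one place only, so the size of this change has not been seen directly. The best guide is compound 1, which carries no phenyl and still gives 470 nM, close to compound 2 at 300 nM. On that basis, no shift beyond the scatter is expected in this assay, with at most a slight drift toward a higher number. The expected step is a 1.3-fold higher number from compound 2 to compound 3 (0.12 log units; within the scatter). For compound 3 the estimated value is 400 nM, with an expected range of 180 nM to 900 nM.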

Compound 3, half-maximal inhibitory concentration: 510 nM
Compound 3: the middle estimate sits 1.3-fold (0.11 log units) below what was measured, within the range that was stated.
By their numbers in this assay, from the lowest: compounds 2, 1 and 3 (each within the scatter of the next).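

In this assay, the exchange of phenyl for fluoro on the aromatic carbon ortho to the bromo group can now be read directly, as a 1.7-fold higher number from compound 2 to compound 3 (0.23 log units; within the scatter), so at this position these three compounds do not separate a phenyl group from a single fluorine. The second exchange, bromo in place of chloro on an aromatic carbon, gives a 1.1-fold higher number from compound 1 to compound 3 (0.04 log units; within the scatter), which means that for this pair the choice between the two halogens does not separate the compounds either. Nothing at hand bears on the reason for these results.

From the compounds shown here alone, only phenyl and fluoro have been seen at the first position and only chloro and bromo at the second, so it remains open whether an amine, a carboxylic acid or a longer chain such as n-butyl would also stay within the scatter at either place. All three compounds carry the hydroxy group and both trifluoromethyl groups unchanged, which leaves open what a methoxy group in place of the hydroxy group would do in this assay.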